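Tolerance of three amides and one unmeasured analogue

The compounds below may be only part of what the source reports. "The series", "measured", "known", "first", "only" and "open" are said of these compounds alone.

Compound 1 `CC(Sc1nnc(-c2ccncc2)s1)C(=O)Nc1ccccc1Cl` in an ADME assay on HepG2 cells (Homo sapiens) for cytotoxicity, with a stated time of 3 days (a lower number here means that less compound is tolerated, a higher number that more compound is tolerated), sits at the assay limit > 50000 nM.
Compound 2 `O=C(CSc1nnc(-c2ccncc2)s1)Nc1ccc(Cl)cc1Cl` in this assay has "not determined" (no result reported).
Compound 3 `O=C(CSc1nnc(-c2ccncc2)s1)NCc1ccc(Cl)cc1` in this assay sits at the assay limit > 50000 nM.

Compound 3 therefore stands not on a number but on a limit of this assay, and among the other two entries one is likewise a limit and one carries no single number at all, so no ordering among the three can be drawn. Within the data shown here, what the set does show is the limit of > 50000 nM in this assay, at which 2 of the 3 values shown sit, which is the only evidence available for this change.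

Compound 4 `O=C(CSc1nnc(-c2ccncc2)s1)Nc1ccccc1Cl` differs from compound 3 in one place: 2-chlorophenyl in place of 4-chlorobenzyl on an amide-type nitrogen. Among the measured compounds shown here, no step between measured compounds exists that would tell how this assay answers to such a replacement on an amide-type nitrogen. With both readable values sitting at the same limit, no step beyond the scatter in either direction is expected from compound 3 to compound 4, and the expected step is a step that the limit leaves unreadable from compound 3 to compound 4. Compound 4 is accordingly estimated at 70000 nM, with a range from 30000 nM to 200000 nM, and most likely only a limit will again be reported.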

Compound 4, half-maximal cytotoxic concentration: > 50000 nM
Compound 4 ended at the assay's limit; the forecaster's own chance of this, stated with the estimate: 80%; the middle value is on the limit's open side.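

Compound 4, like compound 1 and compound 3, stands at a limit of this assay, so neither step to compound 4 can be read: the limit of > 50000 nM in this assay, at which 3 of the 4 values shown sit.

The compounds shown leave open at what concentration any of these amides stops being tolerated, and whether either replacement changes that tolerance at all.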